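A few compounds are considered here, and "the series" means these few. Any claim that something is new, unique, unknown or untested is made for them only; others in the source may bear on it.

In an ADME assay on HepG2 2.2.15 cells (Homo sapiens) for cytotoxicity (on this read-out lower numbers stand for higher toxicity in this test and higher numbers for lower toxicity in this test), compound 1 (`CCCC(=O)OCCc1c(-c2ccccc2Cl)c2cc(Cl)ccc2[nH]c1=O`) gives 52000 nM and compound 2 (`O=C(O)CCCC(=O)OCCc1c(-c2ccccc2Cl)c2cc(Cl)ccc2[nH]c1=O`) gives 110000 nM and so stands higher of the two. Among the measured compounds shown here, only one measured step bears on what follows: a 2.1-fold higher number from compound 1 to compound 2 (0.33 log units; beyond the scatter) when carboxy takes the place of hydrogen on the chain. Compound 3 (`N#CCC(=O)OCCc1c(-c2ccccc2Cl)c2cc(Cl)ccc2[nH]c1=O`) has cyano in place of 2-carboxyethyl on a saturated chain carbon bound to a carbonyl carbon and so, like compound 1, has no carboxy. A similarly modest step down is expected, estimated as a 2.2-fold lower number from compound 2 to compound 3 (0.34 log units; beyond the scatter) and resting on that single step. Compound 3 is estimated at 50000 nM (20000 nM to 120000 nM).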

Compound 3, half-maximal cytotoxic concentration: 100000 nM
The estimate for compound 3 lay 2.0-fold (0.30 log units) below the measured number, within the range that was stated.
By their numbers in this assay, from the lowest: compounds 1, 3 and 2 (each within the scatter of the next, the first and the last beyond it).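

In this assay, cyano in place of 2-carboxyethyl on a saturated chain carbon bound to a carbonyl carbon gives a step within the scatter (a 1.1-fold lower number from compound 2 to compound 3 (0.04 log units; within the scatter)), and cyano in place of ethyl there also stays within it (a 1.9-fold higher number from compound 1 to compound 3 (0.28 log units; within the scatter)). Compound 3 therefore cannot be told apart from compound 1 or compound 2, although those two differ beyond the scatter, so a carboxylic acid is not needed here to match compound 2. Nothing measured here explains this.

Whether an amine, an amide or a longer chain at this place would also fall among these three compounds stays open. So does whether the same holds with a core other than the shared one.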